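This account rests on a few compounds, and the source may have more. Where it says the series, first, only, none or still open, it means among the compounds named here.

Three compounds built on one shared core, differing only in the aryl group carried by an amine nitrogen in a ring, have been tested in an assay on CHO cells for displacement of a labelled ligand from adenosine receptor A1 (Homo sapiens), read by scintillation counting, with a stated time of 90 min, tested at 1 uM, in the presence of a further agent that is not named here; a lower number here means less inhibition, a higher number more inhibition at the concentration tested (going by the name of the read-out). Compound 1 `CCCn1c(=O)[nH]c2nc(-c3ccc(S(=O)(=O)N4CCN(c5ccc(F)cc5)CC4)cc3)[nH]c2c1=O` gives 14% in this assay. Compound 2 `CCCn1c(=O)[nH]c2nc(-c3ccc(S(=O)(=O)N4CCN(c5ccc(Cl)cc5F)CC4)cc3)[nH]c2c1=O` gives 9% in this assay. Compound 3 `CCCn1c(=O)[nH]c2nc(-c3ccc(S(=O)(=O)N4CCN(c5cccc(Br)c5)CC4)cc3)[nH]c2c1=O` gives -1% in this assay, the lowest of the three numbers. Its distance from compound 2 is a number 10 percentage points lower from compound 2 to compound 3 (within the scatter), whereas its distance from compound 1 is a number 15 percentage points lower from compound 1 to compound 3 (beyond the scatter).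

Compound 4 `CCCn1c(=O)[nH]c2nc(-c3ccc(S(=O)(=O)N4CCN(c5ccccc5F)CC4)cc3)[nH]c2c1=O` has not yet been measured. It differs from compound 3 in one place: 2-fluorophenyl in place of 3-bromophenyl on an amine nitrogen in a ring. All three measured steps concern this same aryl group, so all bear on the new one. The step of a number 15 percentage points lower from compound 1 to compound 3 (beyond the scatter) is the only one beyond the scatter, and it runs from a phenyl bearing a single fluorine to 3-bromophenyl. The steps of a number 5 percentage points lower from compound 1 to compound 2 (within the scatter) and a number 10 percentage points lower from compound 2 to compound 3 (within the scatter) stay within the scatter. Among the measured compounds shown here, compound 4 returns to a phenyl bearing a single fluorine, as in compound 1, so a modest rise is expected, roughly a number 11 percentage points higher from compound 3 to compound 4 (beyond the scatter), though with only three measured compounds the basis is thin. For compound 4 in this assay the estimate is 10%, expected to fall between -5% and 25%.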

Compound 4, a percentage reported as inhibition, at one concentration (the size of the read-out at that concentration, not a potency): 13%
Beside the measured number, compound 4's estimate is 3 percentage points below it, and the stated range covers the measured number.
By their numbers in this assay, from the lowest: compounds 3, 2, 4 and 1 (each within the scatter of the next, the first and the last beyond it).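

In this assay the swap to 2-fluorophenyl gives a number 14 percentage points higher from compound 3 to compound 4 (beyond the scatter) and so a second phenyl bearing a single fluorine now stands clear of 3-bromophenyl, while moving that fluorine gives only a number 1 percentage points lower from compound 1 to compound 4 (within the scatter) and makes no readable difference on this amine nitrogen in a ring. Taking the chloro away from compound 2 gives a number 4 percentage points higher from compound 2 to compound 4 (within the scatter) so that group can also go without a readable change, and compound 2 itself goes against any neat split of these aryl groups, since it lies within the scatter of both compound 3 and compound 4. No measurement is at hand that would explain any of these steps.

The compounds shown cannot tell whether it is the bromine itself or where it sits in 3-bromophenyl that sets compound 3 apart from the two compounds with a single fluorine. They also leave open whether a different group on this phenyl, such as a methoxy group, an amine or a carboxylic acid, would move the number further than these halogens do.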